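Cytotoxicity of Tetrazole Anilines: Bromine to Fluorine Swap

This account rests on a few compounds, and the source may have more. Where it says the series, first, only, none or still open, it means among the compounds named here.

Measured compounds:
compound 1 `COc1ccc(Nc2nnnn2-c2ccccc2F)cc1` – 212000 nM
compound 2 `COc1ccc(-n2nnnc2Nc2ccc(Br)cc2)cc1` – 212000 nM
compound 3 `COc1ccc(Nc2nnnn2-c2cccc(F)c2)cc1` – 123000 nM

In an ADME assay on V79 cells (Cricetulus griseus) for cytotoxicity, read by MTT assay, with a stated time of 72 h (a lower number here means a stronger inhibitor, a higher number a weaker inhibitor), compound 2 gives 212000 nM, level at the digits shown with compound 1 and, with it, the highest of the three numbers; compound 3 lies a small step away, within the scatter. The unmeasured compound 4 `COc1ccc(-n2nnnc2Nc2ccccc2F)cc1` differs from compound 2 by 2-fluorophenyl in place of 4-bromophenyl on a nitrogen on an aromatic ring. Going by the values given here, no measured step changes a group on that nitrogen. Among the compounds with values here, the only measured step, a 1.7-fold lower number from compound 1 to compound 3 (0.24 log units; within the scatter), moves a fluorine within a fluorophenyl on the other aromatic nitrogen and stays within the scatter, so no step beyond the scatter is expected for compound 4, a 1.1-fold lower number from compound 2 to compound 4 (0.03 log units; within the scatter). Compound 4 is therefore estimated at 200000 nM, between 100000 nM and 400000 nM.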

Compound 4, half-maximal inhibitory concentration: 115000 nM
The estimate for compound 4 lay 1.7-fold (0.24 log units) above the measured number, within the range that was stated.
By their numbers in this assay, from the lowest: compounds 4, 3, 1 and 2 (each within the scatter of the next).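

In this assay, going by these compounds alone, the change on this nitrogen gives a 1.8-fold lower number from compound 2 to compound 4 (0.27 log units; within the scatter), the first measured step at this position. Swapping 4-bromophenyl for 2-fluorophenyl, which alters both the halogen and where it sits on the phenyl, therefore stays within the scatter. No measurement available here accounts for this result. Within the data shown here, the single step cannot separate the halogen from its placement on the phenyl. As far as these compounds go, whether a carboxylic acid or an amine in place of the 2-fluorophenyl on this nitrogen would move the number beyond the scatter remains open.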